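The source may hold more compounds than are shown below. What is called first, only, known or untested is meant among the compounds shown, and "the series" means these compounds.

Compound 1 `Cc1nc(S(C)(=O)=O)ccc1Oc1ncnc(OC2CCN(C(=O)OC3CCC3)CC2)c1F` gives 167 nM in a functional assay on isolated protein for inhibition of Glucose-dependent insulinotropic receptor (Rattus norvegicus), read by HTRF and cAMP accumulation; on this read-out lower numbers stand for an effect already at smaller amounts and higher numbers for an effect only at larger amounts of compound. Compound 2 `Cc1nc(S(C)(=O)=O)ccc1Oc1ncnc(OC2CCN(C(=O)c3noc(C(C)C)n3)CC2)c1F` gives 176 nM in this assay and stands at the higher of the two numbers shown, though its only neighbour is within the scatter: a 1.1-fold higher number from compound 1 to compound 2 (0.02 log units; within the scatter). Compound 3 `Cc1nc(S(C)(=O)=O)ccc1Oc1ncnc(OC2CCN(C(=O)c3nc(C(C)(C)F)no3)CC2)c1F` carries a group of 9 heavy atoms (5 carbon, 2 nitrogen, 1 oxygen, 1 fluorine; one five-membered aromatic ring with 3 hetero atoms) in place of a group of 8 heavy atoms (5 carbon, 2 nitrogen, 1 oxygen; one five-membered aromatic ring with 3 hetero atoms), on a carbonyl carbon. Within the data shown here, no measured step changes a group on this carbonyl carbon in the same way; the single step recorded at this position stayed within the scatter. For compound 3 the expected step is a 1.0-fold higher number from compound 2 to compound 3 (0.01 log units; within the scatter), nothing beyond the scatter. Compound 3 is therefore estimated at 180 nM, in the range 90 nM to 360 nM.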

Compound 3, half-maximal effective concentration: 606 nM
The estimate for compound 3 lay 3.4-fold (0.53 log units) below the measured number; the measured number lies above the stated range.
By their numbers in this assay, from the lowest: compounds 1 and 2 (each within the scatter of the next); then compound 3.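

The carbonyl carbon whose other neighbour is the ring amide-type nitrogen is not indifferent to its group: in this assay there is a 3.4-fold higher number from compound 2 to compound 3 (0.54 log units; beyond the scatter), and a 3.6-fold higher number from compound 1 to compound 3 (0.56 log units; beyond the scatter). Compound 2 and compound 3 both carry one five-membered aromatic ring with 3 hetero atoms and match in donor and acceptor counts, so these shared counts do not keep the numbers within the scatter. No measurement offers an explanation for this result. Whether the fluorine alone accounts for the step remains open; a tert-butyl or trifluoromethyl group on that ring could help separate this.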